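The source may hold more compounds than are shown below. What is called first, only, known or untested is meant among the compounds shown, and "the series" means these compounds.

Measured in a physicochemical assay for lipophilicity, using the shake flask method, in phosphate buffer, measured as octanol-water partition, with a stated time of 24 h, at pH 7.4, tested at 100 uM; a lower number here means a more polar compound, a higher number a more lipophilic compound:
Compound 1 `Cc1cccc(C)c1-c1cccc(COc2ccc(SCC(=O)O)cc2)c1`: 3.82
Compound 2 `Cc1cccc(C)c1-c1cccc(COc2ccc(S(=O)(=O)CC(=O)O)cc2)c1`: 2.49
Compound 3 `COc1cc(C)c(-c2cccc(COc3ccc4c(c3)S(=O)(=O)CC4CC(=O)O)c2)c(C)c1`: "not determined" (no result reported)

Among the compounds with values here, compound 2 gives 2.49, the lower of the two numbers available, and the only other number is that of compound 1 at 3.82. Compound 3 offers no number for comparison. Compound 4 `Cc1cc(OCC2CC2)cc(C)c1-c1cccc(COc2ccc(S(=O)(=O)CC(=O)O)cc2)c1` carries cyclopropylmethoxy in place of hydrogen on an aromatic carbon. Within the data shown here, the one measured step, a number 1.33 log units lower from compound 1 to compound 2 (beyond the scatter), was large, but it concerns a different change, so it bears on this one only as a yardstick of size. Among the measured compounds shown here, no measured step covers the new change, and the expectation rests on the structural change alone. A rise beyond the scatter, smaller than that measured step, is expected in this assay. The expected step is a number 0.81 log units higher from compound 2 to compound 4 (beyond the scatter). For compound 4 the estimate is 3.3, with an expected range of 2.9 to 3.8.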

Compound 4, distribution coefficient: 3.46
The estimate for compound 4 lay 0.16 log units below the measured number; the range from low to high includes it.
By their numbers in this assay, from the lowest: compound 2; then compound 4; then compound 1.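

In this assay, cyclopropylmethoxy in place of hydrogen, on the aromatic carbon para to a large group and meta to two methyl groups, gives a number 0.97 log units higher from compound 2 to compound 4 (beyond the scatter). Within the data shown here, the only earlier step concerned (carboxymethyl)sulfonyl in place of (carboxymethyl)sulfanyl, so this is the first reading at this position, and it rests on a single pair. Nothing given here accounts for the size of this step. Going by these compounds, whether an amine, a hydroxyl or a longer alkoxy chain at this position would give a similar step remains open. So does whether cyclopropylmethoxy would give the same step in the (carboxymethyl)sulfanyl series.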